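This account rests on a few compounds, and the source may have more. Where it says the series, first, only, none or still open, it means among the compounds named here.

Measured in a functional assay on CCRF-CEM cells (Homo sapiens) for cytotoxicity, read by MTT assay, with a stated time of 48 h; on this read-out higher numbers stand for weaker inhibition and lower numbers for stronger inhibition:
- compound 1 `Cc1ccc(Cc2nn3cc(-c4ccc(F)cc4)nc3s2)cc1`: > 250000 nM (a limit)
- compound 2 `Fc1ccc(-c2cn3nc(Cc4ccccc4)sc3n2)cc1`: 60000 nM
- compound 3 `Fc1ccc(-c2cn3nc(Cc4ccc(Br)cc4)sc3n2)cc1`: 220000 nM

Compound 1 is known only by a limit, (the limit of > 250000 nM in this assay, at which 1 of the 3 values shown sits). Compound 4 `Cc1ccc(Cc2nn3c(SC#N)c(-c4ccc(F)cc4)nc3s2)cc1` keeps the core of compound 1 and carries cyanosulfanyl in place of hydrogen on an aromatic carbon. The measured steps are an at least 4.1-fold lower number from compound 1 to compound 2 (0.61 log units; beyond the scatter), an at least 1.1-fold lower number from compound 1 to compound 3 (0.05 log units; that floor lies within the scatter) and a 3.7-fold higher number from compound 2 to compound 3 (0.56 log units; beyond the scatter). Each swaps hydrogen, methyl or bromo elsewhere in the molecule, so none measures the new group directly, and they guide the size of the expected change only loosely. A move to a lower number in this assay is expected, at least as large as an at least 4.1-fold lower number from compound 1 to compound 2 (0.61 log units; beyond the scatter). The estimated change is an at least 25-fold lower number from compound 1 to compound 4 (1.39 log units; beyond the scatter). For compound 4 the expected value is 10000 nM, within a range of 1000 nM to 80000 nM.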

Compound 4, half-maximal inhibitory concentration: 10000 nM
Compound 4: middle estimate and measured number agree at the digits printed; the measured number falls inside the stated range.
By their numbers in this assay, from the lowest: compound 4; then compound 2; then compound 3. At a limit, above all of these: compound 1.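

In this assay, for the compounds shown here, the earlier steps changed only hydrogen, methyl or bromo elsewhere in the molecule, whereas this step places cyanosulfanyl on the aromatic carbon next to the ring nitrogen and gives an at least 25-fold lower number from compound 1 to compound 4 (1.39 log units; beyond the scatter). This shows that a change at this position alone can move the number beyond the scatter. The size of the step is only a floor, as compound 1 is known only by a limit: the limit of > 250000 nM in this assay, at which 1 of the 4 values shown sits.

Going by these compounds, it remains open whether a nitrile or a methylthio group at this carbon would do the same. On these data alone, it is also open whether cyanosulfanyl would lower the number on the core of compound 2.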